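Ethyl to Methyl on the Piperazine of Compound 1

The source may hold more compounds than are shown below. What is called first, only, known or untested is meant among the compounds shown, and "the series" means these compounds.

Measured in a functional assay on CCRF-CEM cells for antagonist activity at C-X-C chemokine receptor type 4 (Homo sapiens), read by calcium flux, with stated times of 25 min and 90 s; on this read-out higher numbers stand for weaker inhibition and lower numbers for stronger inhibition:
compound 1 `CCN1CCN(c2cccc3c2C[C@H](CN(C)[C@H]2CCCc4cccnc42)NC3)CC1`: 13.8 nM
compound 2 `FC1(F)CCC(CN(C[C@H]2Cc3c(cccc3N3CCNCC3)CN2)[C@H]2CCCc3cccnc32)CC1`: 498 nM
compound 3 `CC(C)N(C[C@H]1Cc2c(cccc2N2CCNCC2)CN1)[C@H]1CCCc2cccnc21`: 364 nM

Compound 1 gives the lowest number of the three. Compound 3 at 364 nM and compound 2 at 498 nM both stand beyond the scatter above it, so compound 1 is the most potent compound in this set on this read-out.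

Compound 4 `CN1CCN(c2cccc3c2C[C@H](CN(C)[C@H]2CCCc4cccnc42)NC3)CC1` is the next compound to be measured. It differs from compound 1 in one place: hydrogen in place of methyl on a saturated chain carbon bound to an amine nitrogen in a ring. For the measured compounds named here, the only measured step, a 1.4-fold lower number from compound 2 to compound 3 (0.14 log units; within the scatter), concerns the substituent on the other amine nitrogen, not the piperazine, so it does not bear directly on this change; it shows only that a change of alkyl on a nitrogen can leave the number where it was. Going by the values given here, with no step at the piperazine to draw on, the expected step of a 1.3-fold higher number from compound 1 to compound 4 (0.12 log units; within the scatter) is small and within the scatter. Compound 4 is therefore estimated at 18 nM, with a range from 7 nM to 45 nM.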

Compound 4, half-maximal inhibitory concentration: 29.6 nM
For compound 4 the middle estimate is 1.6-fold (0.22 log units) below the measured one; the range from low to high includes it.
By their numbers in this assay, from the lowest: compound 1; then compound 4; then compounds 3 and 2 (each within the scatter of the next).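

In this assay, for the compounds shown here, the step at the piperazine, a 2.1-fold higher number from compound 1 to compound 4 (0.33 log units; beyond the scatter), is the first measured change at this position, and unlike the one earlier step, it lies beyond the scatter. Going from 4-ethylpiperazin-1-yl to 4-methylpiperazin-1-yl therefore moves the number modestly in the direction of weaker inhibition, so the removal of this one carbon is detectable, though the effect is not large. No measurement shown here explains the shift.

The compounds shown leave open how a longer chain such as propyl, or a carboxylic acid on a chain at this place, would read. They also leave open whether the ethyl to methyl step would keep its size with a group other than methyl on the other amine nitrogen.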